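The source may hold more compounds than are shown below. What is called first, only, known or untested is meant among the compounds shown, and "the series" means these compounds.

The measured compounds:

Compound 1 `CCCc1nc(C)c2c(CC)nnc(SC)n12` gives in a functional assay for inhibition, with Homo sapiens as the target (a lower number here means a stronger inhibitor, a higher number a weaker inhibitor), the value > 48000 nM, which is a limit of the assay.
Compound 2 `CCCc1nc(C)c2c(CC)nnc(S)n12` gives in this assay the value > 48000 nM, again a limit of the assay.
Compound 3 `CCCc1ncn2c(S)nncc12` gives in this assay the value > 48000 nM, also a limit of the assay.

Compound 2 and compound 1 share a core and differ by methyl in place of hydrogen on a sulfur. The step between them, a step that the two limits leave unreadable from compound 2 to compound 1, cannot be read, since both values are limits. The difference between the core of compound 2 and the core of compound 3 is not broken down here.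

Compound 4 `CCCc1ncn2c(SC)nncc12` has not yet been measured in this assay. It differs from compound 3 by methyl in place of hydrogen on a sulfur, the same change that separates compound 2 from compound 1. Because the limit of > 48000 nM in this assay, at which 3 of the 3 values shown sit, holds every value shown, compound 3 offers no number from which a step could be read off. Compound 4 is therefore estimated to give about 100000 nM, most likely again reported as a limit, with an expected step that the limit leaves unreadable from compound 3 to compound 4.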

Compound 4, half-maximal inhibitory concentration: > 48000 nM
Compound 4 was reported as a limit; the forecaster's own chance of this, stated with the estimate: 85%; the middle value does not contradict the limit.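

In this assay compound 4 gives > 48000 nM, which is a limit of the assay. No step can be read between compound 3 and compound 4, because all the compounds sit at one limit: the limit of > 48000 nM in this assay, at which 4 of the 4 values shown sit.

The compounds shown leave open how strongly any of the four inhibits, and whether methyl in place of hydrogen on a sulfur changes inhibition at all.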